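A single potency figure and one aryl swap

The source may hold more compounds than are shown below. What is called first, only, known or untested is meant among the compounds shown, and "the series" means these compounds.

Measured in a functional assay on EBC-1 cells (Homo sapiens) for antiproliferative activity, with a stated time of 72 h; on this read-out higher numbers stand for weaker inhibition and lower numbers for stronger inhibition:
compound 1 `Cn1cc(-c2cc(Cl)c3ncc(Cc4ccc5ncccc5c4)n3c2)cn1`: "not determined" (no result reported)
compound 2 `Cn1cc(-c2cn3c(Cc4ccc5ncccc5c4)cnc3cc2C(F)(F)F)cn1`: "not determined" (no result reported)
compound 3 `OCCn1cc(-c2cc(F)c3ncc(Cc4ccc5ncccc5c4)n3c2)cn1`: 0.34 nM

Only compound 3 carries a number in this assay, so it can be ranked against nothing. Among the measured compounds shown here, compounds 1 and 2 offer no comparison, and no step between measured compounds exists to guide the next prediction.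

The next compound is compound 4 `N#Cc1ccc(-c2cc(F)c3ncc(Cc4ccc5ncccc5c4)n3c2)cc1F`, still awaiting its measurement. It keeps the core of compound 3 but has 4-cyano-3-fluorophenyl in place of 1-(2-hydroxyethyl)-1H-pyrazol-4-yl on an aromatic carbon.

For the measured compounds named here, with no measured precedent for this exchange, the forecast is necessarily loose. Compound 3 sits at a very low 0.34 nM, and a replacement of this size is more likely to give weaker than stronger inhibition from such a starting point. The expected change is a clear weakening, estimated as a 24-fold higher number from compound 3 to compound 4 (1.37 log units; beyond the scatter). In this assay the estimate for compound 4 is 8 nM, with an expected range from 1 nM to 60 nM.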

Compound 4, half-maximal inhibitory concentration: 145 nM
Beside the measured number, compound 4's estimate is 18-fold (1.26 log units) below it; the whole stated range lies below it.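

In this assay, among the compounds shown here, the group on this aromatic carbon proves to matter a great deal: 4-cyano-3-fluorophenyl in place of 1-(2-hydroxyethyl)-1H-pyrazol-4-yl gives a 430-fold higher number from compound 3 to compound 4 (2.63 log units; beyond the scatter) and so much weaker inhibition, the first reading of any change at this position. The exchange alters several things at once, since a five-membered aromatic ring with 2 hetero atoms and 1 hydrogen-bond donor gives way to a six-membered aromatic ring of carbon only with 0 hydrogen-bond donors. Nothing measured here accounts for the loss.

As far as these compounds go, it remains open whether the ring or the hydroxyethyl chain carries the difference. A pyrazole bearing a 2-aminoethyl or a 3-hydroxypropyl chain, or a phenyl ring bearing a 2-hydroxyethyl chain, would begin to separate the two.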